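The compounds below may be only part of what the source reports. "The series", "measured", "known", "first", "only" and "open" are said of these compounds alone.

Going by the values given here, in an ADME assay on a cell-free system (plasma, Homo sapiens) for metabolic stability (on this read-out lower numbers stand for a shorter-lived compound and higher numbers for a longer-lived compound), two compounds have numbers so far. Compound 1 `CC(C)(C)C(=O)OCN(c1ccc([N+](=O)[O-])cc1Oc1ccccc1)S(C)(=O)=O` gives 1.7 h, and compound 2 `N[C@@H](CC(=O)O)C(=O)O[C@H]1C[C@H](n2cc(F)c(=O)[nH]c2=O)O[C@@H]1CO` gives 0.898 h. These two values lie within the usual scatter of repeated measurements, so compound 2 stands level with compound 1 and no order can be read from the pair. Among the compounds with values here, the two compounds also do not differ in just one place, so no measured step shows how far a single structural change can move the half-life.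

Compound 3 `O=C(O[C@H]1C[C@H](n2cc(F)c(=O)[nH]c2=O)O[C@@H]1CO)[C@@H]1CCCN1` has not yet been measured. It keeps the rest of compound 2 and differs in one group on a carbonyl carbon: pyrrolidin-2-yl in place of 1-amino-2-carboxyethyl on a carbonyl carbon. Put simply, pyrrolidin-2-yl stands in place of 1-amino-2-carboxyethyl. Within the data shown here, with no measured step as a guide, this expectation is tentative: a modest lengthening of the half-life, perhaps one that does not clear the scatter. The expected size of the change is a 1.7-fold higher number from compound 2 to compound 3 (0.22 log units; within the scatter). For compound 3, the estimated half-life is 1.5 h, with an expected range from 0.4 h to 5 h.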

Compound 3, half-life: 0.23 h
Compound 3: middle estimate off by 6.5-fold (0.81 log units), on the high side; measured number outside the range, below it.
By their numbers in this assay, from the lowest: compound 3; then compounds 2 and 1 (each within the scatter of the next).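

In this assay, putting pyrrolidin-2-yl in place of 1-amino-2-carboxyethyl on a carbonyl carbon gives a 3.9-fold lower number from compound 2 to compound 3 (0.59 log units; beyond the scatter), so a change at this position can move the half-life by more than the usual scatter, something the earlier pair could not show. The direction is toward a shorter-lived compound, and the swap alters several things at once: a five-membered ring enters, the open chain leaves, and both oxygen atoms of the departing group go with it. Going by these compounds alone, nothing measured here explains the step, so the half-life shows only that this swap matters, not which part of it does.

The compounds shown leave open whether the ring or the missing carboxylic acid accounts for the step, and an open-chain group carrying an amine but no carboxylic acid on the same carbonyl carbon would help separate the two. They also leave open whether ring size counts, which a six-membered piperidin-2-yl group at this place would test against the pyrrolidin-2-yl group of compound 3.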